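Moving the Thiazole Attachment in Compound 3

The source may report more compounds than this note shows. Statements on the series, on what has been measured and on what is new or still open speak of the compounds shown alone.

Compound 2 `CCN(Cc1ccccc1)C(=O)COc1ccc(C)cc1` carries a benzyl group on its amide-type nitrogen, and in an assay on HEK293 cells for agonist activity at transient receptor potential cation channel subfamily M member 8 (Homo sapiens), read by fluorescence and calcium flux, with a stated time of 15 min (a higher number here means that more compound is needed for the effect, a lower number that less compound is needed), compound 2 gives 1880 nM. Among the two compounds measured so far it has the highest number, but its only neighbour, compound 1 `CCN(Cc1cncs1)C(=O)COc1ccc(C)cc1`, with 1100 nM, lies close: the step of a 1.7-fold higher number from compound 1 to compound 2 (0.23 log units; within the scatter) stays within the scatter of this assay, so no order between the two can be read. Compound 3 `CCN(Cc1nccs1)C(=O)COc1ccc(C)cc1` has not yet been measured. It differs from compound 2 by 1,3-thiazol-2-yl in place of phenyl on a saturated chain carbon bound to an amide-type nitrogen. Within the data shown here, the one measured step that bears on this change is a 1.7-fold higher number from compound 1 to compound 2 (0.23 log units; within the scatter), the exchange of 1,3-thiazol-5-yl for phenyl, which was within the scatter; compound 3 puts a thiazole back in place of the phenyl, though as the 1,3-thiazol-2-yl isomer, and the two thiazole isomers have never been compared directly. Among the measured compounds shown here, with that single step as the only guide, the expected step is a 1.4-fold lower number from compound 2 to compound 3 (0.16 log units; within the scatter), nothing beyond the scatter. Compound 3 is therefore estimated at 1300 nM, with a range from 500 nM to 3500 nM.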

Compound 3, half-maximal effective concentration: 3060 nM
Compound 3: middle estimate off by 2.4-fold (0.37 log units), on the low side, and the stated range covers the measured number.
By their numbers in this assay, from the lowest: compounds 1, 2 and 3 (each within the scatter of the next, the first and the last beyond it).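

The new information lies in the direct comparison of the two thiazole isomers: in this assay, moving the ring attachment gives a 2.8-fold higher number from compound 1 to compound 3 (0.44 log units; beyond the scatter) and this modest step is the first among these compounds to pass beyond the scatter. At this place, on a saturated chain carbon bound to an amide-type nitrogen, the attachment point of the thiazole can therefore be read, with 1,3-thiazol-5-yl giving the lower number, so "thiazole" alone does not describe the group. Replacing phenyl with 1,3-thiazol-2-yl gives a 1.6-fold higher number from compound 2 to compound 3 (0.21 log units; within the scatter) and so sets no order between those two compounds, which leaves phenyl within the scatter of both thiazoles even though the thiazoles are separated from each other, and nothing at hand accounts for the gap between the isomers.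

Still open, as far as these compounds go, is whether a 1,3-thiazol-4-yl, a 1,3-oxazol-2-yl or a pyridin-2-yl ring at the same place would lie with compound 1 or with compound 3. From the compounds shown here alone, it is also open whether the gap between the isomers would persist with a longer chain on the amide-type nitrogen.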